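Chain extension and piperidine swap: a solubility outlook

The source may hold more compounds than are shown below. What is called first, only, known or untested is meant among the compounds shown, and "the series" means these compounds.

Measured so far:
compound 1 `Cc1ccccc1-c1nc(CN2CCC(C(=O)NCCCN3CCC(C)(C)CC3)CC2)c(C)o1` — > 69 ug/mL
compound 2 `Cc1oc(-c2c(F)cccc2F)nc1CN1CCC(C(=O)NCCCN2C[C@H](C)C[C@H](C)C2)CC1` — > 72 ug/mL
compound 3 `Cc1oc(-c2c(Cl)cccc2Br)nc1CN1CCC(C(=O)NCCCN2C[C@H](C)C[C@H](C)C2)CC1` — > 83 ug/mL

In a physicochemical assay for solubility, in phosphate buffer, measured as kinetic solubility, at pH 7.4 (on this read-out higher numbers stand for higher solubility and lower numbers for lower solubility), compound 1 gives > 69 ug/mL, which is a limit of the assay and not a number (the limit of > 69 ug/mL in this assay, at which 1 of the 3 values shown sits). Compound 2 gives > 72 ug/mL, also a limit (the limit of > 72 ug/mL in this assay, at which 1 of the 3 values shown sits). Compound 3 gives > 83 ug/mL, again a limit (the limit of > 83 ug/mL in this assay, at which 1 of the 3 values shown sits). All three values therefore sit at limits, and the step that the two limits leave unreadable from compound 2 to compound 3 cannot be read in size. Compound 1 thus stands where every value shown stands: at a limit.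

Compound 4 `Cc1ccccc1-c1nc(CN2CCC(C(=O)NCCCCN3C[C@H](C)C[C@H](C)C3)CC2)c(C)o1` differs from compound 1 by (3,5-dimethylpiperidin-1-yl)methyl in place of 4,4-dimethylpiperidin-1-yl on a saturated chain carbon, three bonds along the chain from an amide-type nitrogen. Going by the values given here, no measured step covers this change directly. Compounds 2 and 3, which carry the 3,5-dimethylpiperidin-1-yl group on a longer chain than compound 1, both sit at limits, as does compound 1 itself. No step beyond the scatter is therefore expected in this assay, and the estimated step is a step that the limit leaves unreadable from compound 1 to compound 4. Compound 4 is expected at 80 ug/mL, within 40 ug/mL to 160 ug/mL, most likely reported again as a limit.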

Compound 4, solubility: > 71 ug/mL
Compound 4 gave a limit, no number; the forecaster's own chance of this, stated with the estimate: 75%; the middle value is on the limit's open side.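

In this assay, going by these compounds alone, compound 4 and compound 1 both give a limit rather than a number, so no step between them can be read. The compounds shown leave open the actual solubility of each compound, and whether the change from compound 1 to compound 4 alters it.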